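The source may hold more compounds than are shown below. What is called first, only, known or untested is meant among the compounds shown, and "the series" means these compounds.

Among the compounds with values here, compound 1 `C=CC(=O)Nc1cccc(Nc2ncnc(Nc3ccc(C(=O)Nc4ccccn4)cc3)n2)c1` is a weak inhibitor in a functional assay on Raji cells (Homo sapiens) for antiproliferative activity, read by CCK-8 assay, with a stated time of 24 h (a lower number here means a stronger inhibitor, a higher number a weaker inhibitor), giving 15600 nM, the second highest of the three numbers known. Compound 3 `C=CC(=O)Nc1cccc(Nc2ncnc(Nc3ccc(C(=O)N4CCCCC4)cc3)n2)c1` gives 5140 nM, and compound 2 `C=CC(=O)Nc1cccc(Nc2nc(N)nc(Nc3ccc(OCCOC)cc3)n2)c1` gives 18300 nM. Compound 4 `C=CC(=O)Nc1cccc(Nc2ncnc(Nc3ccc(OC)cc3)n2)c1` differs from compound 1 at the amide: methoxy in place of (pyridin-2-yl)carbamoyl on an aromatic carbon. Within the data shown here, the one step that touches this amide, a 3.0-fold lower number from compound 1 to compound 3 (0.48 log units; beyond the scatter), shows the (pyridin-2-yl)amino part can go without loss. Compound 2 differs from compound 1 in two places, so its value only hints that an alkoxy group here leaves the number near where compound 1 sits. The expected step is therefore small, a 1.3-fold lower number from compound 1 to compound 4 (0.11 log units; within the scatter). Compound 4 is thus estimated at 12000 nM, within a range of 5000 nM to 30000 nM.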

Compound 4, half-maximal inhibitory concentration: 14500 nM
Compound 4: middle estimate off by 1.2-fold (0.08 log units), on the low side; the measured number falls inside the stated range.
By their numbers in this assay, from the lowest: compound 3; then compounds 4, 1 and 2 (each within the scatter of the next).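

Putting methoxy in place of the whole (pyridin-2-yl)carbamoyl, with its six-membered aromatic ring and its hydrogen-bond donor, costs nothing measurable in this assay (a 1.1-fold lower number from compound 1 to compound 4 (0.03 log units; within the scatter)). Of the three groups compared on this aromatic carbon, only (piperidin-1-yl)carbonyl stands apart (a 2.8-fold higher number from compound 3 to compound 4 (0.45 log units; beyond the scatter)), so the size of the group alone does not set the number here. No measured property of these groups is available to explain this. As far as these compounds go, whether an amine, a carboxylic acid or a longer chain on this carbon would sit nearer compound 3 or compound 4 remains open.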